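Two Limits and a Pyrimidinyl Replacement

The source may report more compounds than this note shows. Statements on the series, on what has been measured and on what is new or still open speak of the compounds shown alone.

Compound 1, `Cc1nc2c(cnn2CC2CCCCC2)c(=O)n1-c1ccc(Cl)cc1`, in an in vitro functional assay on cells for antagonist activity at metabotropic glutamate receptor 5 (Homo sapiens), read by FLIPR and calcium flux; on this read-out lower numbers stand for stronger inhibition and higher numbers for weaker inhibition: compound 1 gives > 100000 nM, a limit of the assay.
Compound 2, `Cc1nc2c(cnn2-c2cccc(Cl)c2)c(=O)n1-c1ccc(Cl)cc1`, in this assay: compound 2 gives > 100000 nM, also a limit.

Compound 2 therefore stands at the limit, not at a number. Among the compounds with values here, the only measured step, a step that the two limits leave unreadable from compound 1 to compound 2, is unreadable, and the limit of > 100000 nM in this assay, at which 2 of the 2 values shown sit, is all the evidence there is. Compound 3, `Cc1nc2c(cnn2-c2cncnc2)c(=O)n1-c1ccc(Cl)cc1`, carries pyrimidin-5-yl in place of 3-chlorophenyl on an aromatic nitrogen. Within the data shown here, no measured step bears on this change, so no shift beyond the scatter is expected in this assay; the estimated step is a step that the limit leaves unreadable from compound 2 to compound 3. Compound 3 is expected to give about 150000 nM, estimated between 30000 nM and 1000000 nM.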

Compound 3, half-maximal inhibitory concentration: > 100000 nM
Compound 3: no number, only a limit (the forecaster's own chance of this, stated with the estimate: 85%); the middle value lies beyond the limit too.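

Compound 1, compound 2 and compound 3 all stand at a limit of the assay, so no step among them can be read: the limit of > 100000 nM in this assay, at which 3 of the 3 values shown sit.

The compounds shown leave open whether any group on the aromatic nitrogen would give a measurable value in this assay.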